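Restoring the carbonyl: a furan amide for compound 4

The compounds below may be only part of what the source reports. "The series", "measured", "known", "first", "only" and "open" are said of these compounds alone.

Compound 3 `COc1ccc(S(=O)(=O)N2CCc3cccc(NCc4ccccc4)c32)cc1` stands at the edge of a functional assay on MKN-45 cells (Homo sapiens) for cytotoxicity; a lower number here means a stronger inhibitor, a higher number a weaker inhibitor: its reading of > 10000 nM is a limit of the assay rather than a number (the limit of > 10000 nM in this assay, at which 1 of the 3 values shown sits). Compound 1 `COc1ccc(S(=O)(=O)N2CCc3cccc(NC(=O)c4ccc(C#N)cc4)c32)cc1` gives 89 nM in this assay, and compound 2 `COc1ccc(C(=O)Nc2cccc3c2N(S(=O)(=O)c2ccc(OC)cc2)CC3)cc1` gives 1600 nM. The change to compound 4 `COc1ccc(S(=O)(=O)N2CCc3cccc(NC(=O)c4ccco4)c32)cc1` is (furan-2-yl)carbonyl in place of benzyl on a nitrogen on an aromatic ring. For the measured compounds named here, two measured steps bear on it, an at least 110-fold higher number from compound 1 to compound 3 (2.05 log units; beyond the scatter) and an at least 6.2-fold higher number from compound 2 to compound 3 (0.79 log units; beyond the scatter), each running the opposite way, an aroyl carbonyl replaced by benzyl. Putting a carbonyl back in compound 4 is therefore expected to give a large step to a lower number, estimated as an at least 16-fold lower number from compound 3 to compound 4 (1.22 log units; beyond the scatter). Compound 4 is expected at about 600 nM, within 100 nM to 5000 nM.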

Compound 4, half-maximal inhibitory concentration: 10.7 nM
Compound 4: the middle estimate sits 56-fold (1.75 log units) above what was measured, and the stated range ends above it.
By their numbers in this assay, from the lowest: compound 4; then compound 1; then compound 2. At a limit, above all of these: compound 3.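

With the carbonyl kept, the group on it still decides much of the outcome in this assay: furan-2-yl in place of the substituted phenyl rings gives a 150-fold lower number from compound 2 to compound 4 (2.17 log units; beyond the scatter) and an 8.3-fold lower number from compound 1 to compound 4 (0.92 log units; beyond the scatter). Against benzyl on the same nitrogen, the furan amide gives an at least 930-fold lower number from compound 3 to compound 4 (2.97 log units; beyond the scatter), so that step is a bound and not an exact size. The reading of compound 3 is a limit and not a number: the limit of > 10000 nM in this assay, at which 1 of the 4 values shown sits.

On these data alone, what a thiophene, a pyridine or an unsubstituted phenyl on the same carbonyl would give remains open. So does the effect of a methyl on the amide nitrogen.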